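The compounds below may be only part of what the source reports. "The series", "measured", "known", "first", "only" and "open" are said of these compounds alone.

Measured so far:
- compound 1 `COc1ccc2nc(C)cc(NCc3cccc(F)c3)c2c1`: 14700 nM
- compound 2 `COc1ccc2nc(C)cc(NCc3ccc(F)c(F)c3)c2c1`: 12000 nM

Both values come from a functional assay on MCF-10A cells (Homo sapiens) for antiproliferative activity, with a stated time of 48 h; a higher number here means that more compound is needed for the effect, a lower number that less compound is needed. For the measured compounds named here, compound 2 cannot be told apart from compound 1 on these numbers, since the only measured step is a 1.2-fold lower number from compound 1 to compound 2 (0.09 log units; within the scatter).

The next compound, compound 3 `COc1ccc2nc(C)cc(NCc3ccc(F)c(C(F)(F)F)c3)c2c1`, differs from compound 2 in one place: trifluoromethyl in place of fluoro on an aromatic carbon. Here, trifluoromethyl stands in place of fluoro on an aromatic carbon, ortho to a fluoro group.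

Going by the values given here, only one measured step bears on this change, and it is a loose guide. Among the compounds with values here, in a 1.2-fold lower number from compound 1 to compound 2 (0.09 log units; within the scatter), fluoro replaced hydrogen, and no compound here yet carries trifluoromethyl. With that single small precedent, no step beyond the scatter is expected in this assay. The expected step is a 1.2-fold lower number from compound 2 to compound 3 (0.08 log units; within the scatter). Compound 3 is expected at about 10000 nM, with an estimated range of 4000 nM to 25000 nM.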

Compound 3, half-maximal effective concentration: 14300 nM
For compound 3 the middle estimate is 1.4-fold (0.16 log units) below the measured one, within the range that was stated.
By their numbers in this assay, from the lowest: compounds 2, 3 and 1 (each within the scatter of the next).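

In this assay, putting trifluoromethyl in place of fluoro at this position, ortho to a fluoro group, gives a 1.2-fold higher number from compound 2 to compound 3 (0.08 log units; within the scatter), so the two compounds cannot be told apart. For this one pair, then, the position takes a group with more heavy atoms than fluoro, and the assay shows no change that can be read. No measurement is at hand that could explain this flat result.

On these data alone, it remains open whether a group of a different kind at this position, such as an amine or a carboxylic acid, would shift the number beyond the scatter. Also open, as far as these compounds go, is whether a longer chain, such as an ethyl or propyl group, would leave the number as unchanged as trifluoromethyl does.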